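Chloro on the Bicyclic Ring of a Urea Series

The source may hold more compounds than are shown below. What is called first, only, known or untested is meant among the compounds shown, and "the series" means these compounds.

Measured compounds:
Compound 1 `CC(C)(C)c1cc(NC(=O)Nc2ccc(-c3cn4ccccc4n3)cc2)no1`, which in a functional assay on MV4-11 cells (Homo sapiens) for cytotoxicity, read by MTT assay, with a stated time of 72 h (on this read-out higher numbers stand for weaker inhibition and lower numbers for stronger inhibition), gives 3.09 nM.
Compound 2 `CC(C)(C)c1cc(NC(=O)Nc2ccc(-c3cc4ccccc4s3)cc2)no1`, for which this assay reports only a limit, > 900 nM.
Compound 3 `Cc1cccn2cc(-c3ccc(NC(=O)Nc4cc(C(C)(C)C)on4)cc3)nc12`, which in this assay gives 248 nM.

Compound 1 stands lowest of the two numbers recorded; the nearest is compound 3, reached by an 80-fold higher number from compound 1 to compound 3 (1.90 log units; beyond the scatter). Compound 2 sits at the limit of > 900 nM in this assay, at which 1 of the 3 values shown sits.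

Compound 4 `CC(C)(C)c1cc(NC(=O)Nc2ccc(-c3cn4ccc(Cl)cc4n3)cc2)no1` differs from compound 1 by chloro in place of hydrogen on an aromatic carbon. For the measured compounds named here, two measured steps bear on this change. The step of an 80-fold higher number from compound 1 to compound 3 (1.90 log units; beyond the scatter) also adds a small group to the same six-membered ring of the shared core, though at another position, and it was large. The step of an at least 290-fold higher number from compound 1 to compound 2 (2.46 log units; beyond the scatter) exchanges the whole bicyclic group and is therefore a looser guide. Since a single added group on this ring already cost compound 3 the step of an 80-fold higher number from compound 1 to compound 3 (1.90 log units; beyond the scatter), a weakening beyond the scatter is expected for compound 4, though its size is uncertain because a chloro at a different place need not match a methyl. Compound 4 is estimated at 40 nM, within 6 nM to 300 nM, which corresponds to an expected step of a 13-fold higher number from compound 1 to compound 4 (1.11 log units; beyond the scatter).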

Compound 4, half-maximal inhibitory concentration: 5.91 nM
Estimate against measurement, compound 4: 6.8-fold (0.83 log units) above, outside the stated range (below it).
By their numbers in this assay, from the lowest: compounds 1 and 4 (each within the scatter of the next); then compound 3. At a limit, above all of these: compound 2.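

In this assay, chloro in place of hydrogen on the aromatic carbon opposite the ring nitrogen gives a 1.9-fold higher number from compound 1 to compound 4 (0.28 log units; within the scatter), so this position of the six-membered ring accepts a chlorine without a change beyond the scatter. An added group on this ring therefore does not carry a large cost in every case, although the step of an 80-fold higher number from compound 1 to compound 3 (1.90 log units; beyond the scatter) shows that it can; that step has a methyl at another position, so group and place change together between the two comparisons. Nothing measured in the compounds shown explains why the chloro is accepted here.

As far as these compounds go, it remains open whether a methyl at this position would behave like the chloro, or whether a chloro at the methyl's position in compound 3 would behave like that methyl. From the compounds shown here alone, how a larger or charged group at this position, such as a methoxy, an amine or a carboxylic acid, would fare also remains open.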